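Series notes: aryl exchange at the exocyclic double bond

This account rests on a few compounds, and the source may have more. Where it says the series, first, only, none or still open, it means among the compounds named here.

Measured so far:
compound 1, `CCOC(=O)C1=C(Nc2ccccc2)S/C(=C\c2ccc(O)c(O)c2)C1=O`: 48.7%
compound 2, `CCOC(=O)C1=C(Nc2ccccc2)S/C(=C\c2cc(OC)c(O)c(OC)c2)C1=O`: 57.5%

In a functional assay on JAR cells (Homo sapiens) for inhibition, read by MTT assay, with a stated time of 72 h, tested at 10 uM (on this read-out higher numbers stand for more inhibition at the one concentration tested (going by the name of the read-out) and lower numbers for less inhibition), compound 1 gives 48.7%, the lower of the two numbers; compound 2 gives 57.5%, and the gap between them is within the scatter, so the two compounds read as equivalent on this assay. Both share the same core, and they differ only in the aryl part attached at the exocyclic double bond.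

Compound 3, `CCOC(=O)C1=C(Nc2ccccc2)S/C(=C\c2cc3ncccc3[nH]2)C1=O`, has not been measured. Relative to compound 1 the change is a group of 9 heavy atoms (7 carbon, 2 nitrogen; one five-membered aromatic ring with 1 hetero atom, one six-membered aromatic ring with 1 hetero atom) in place of a group of 8 heavy atoms (6 carbon, 2 oxygen; one six-membered aromatic ring of carbon only), on a double-bonded chain carbon bound to a double-bonded ring carbon. Among the measured compounds shown here, no measured pair shows a step of this kind, so its size has to be guessed. For the measured compounds named here, since the one aryl exchange seen so far stays within the scatter, no step beyond the scatter is expected here either. Compound 3 is therefore expected at 50%, with a range from 25% to 75%, because compound 1 gives 48.7%. The expected step is a number 1.3 percentage points higher from compound 1 to compound 3 (within the scatter).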

Compound 3, a percentage reported as inhibition, at one concentration (the size of the read-out at that concentration, not a potency): 74.8%
For compound 3 the middle estimate is 24.8 percentage points below the measured one, within the range that was stated.
By their numbers in this assay, from the lowest: compounds 1 and 2 (each within the scatter of the next); then compound 3.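

Putting the group with one five-membered aromatic ring with 1 hetero atom and one six-membered aromatic ring with 1 hetero atom in place of 3,4-dihydroxyphenyl, on a double-bonded chain carbon bound to a double-bonded ring carbon, gives a number 26.1 percentage points higher from compound 1 to compound 3 (beyond the scatter) in this assay on the shared core. Among the compounds shown here, the earlier pair stayed within the scatter, so this is the first sign that the aryl exchange at this place can shift the read-out. No measurement at hand speaks to what lies behind the shift.

From the compounds shown here alone, one exchange removes the two hydroxyl groups and brings in both new rings, so the contribution of each remains open. An unsubstituted phenyl or a pyridyl group at this place would begin to separate them, and a single concentration leaves potency open.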